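Series notes: the step from compound 1 to compound 3

This account rests on a few compounds, and the source may have more. Where it says the series, first, only, none or still open, it means among the compounds named here.

Two compounds of the series have been run in a physicochemical assay for lipophilicity; on this read-out higher numbers stand for higher lipophilicity and lower numbers for lower lipophilicity. Compound 1 `CC(C)Sc1nnc(-c2c(CN3CCC(N4CCCC4)CC3)c3ccccc3n2C)n1-c1ccccc1` gives 5.16 in this assay. Compound 2 `COc1cccc(CNCc2c(-c3nnc(SC(C)C)n3-c3ccccc3)n(C)c3ccc(F)cc23)c1` gives 6.42. Compound 1 therefore stands lowest of the two numbers, with compound 2 as its nearest neighbour at a value higher by a margin beyond the scatter. Within the data shown here, no single-point step between these two measured compounds is in hand, so their two values are all that can be said of them.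

Compound 3 `CC(C)Sc1nnc(-c2c(CNCCN3CCCC3)c3ccccc3n2C)n1-c1ccccc1` has not yet been measured. It differs from compound 1 in one place: (2-(pyrrolidin-1-yl)ethyl)amino in place of 4-(pyrrolidin-1-yl)piperidin-1-yl on a saturated chain carbon bound to an aromatic carbon. The entering group counts one hydrogen-bond donor; the leaving group counts none. Among the measured compounds shown here, with no measured step of this kind available, the expectation rests on compound 1 at 5.16 and on the change itself: the step of a number 0.76 log units lower from compound 1 to compound 3 (beyond the scatter) is expected to be a decrease beyond the scatter. Compound 3 is accordingly estimated at 4.4, with a range from 3.8 to 5.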

Compound 3, partition coefficient: 4.83
Compound 3: the middle estimate sits 0.43 log units below what was measured; measured number inside the range.
By their numbers in this assay, from the lowest: compound 3; then compound 1; then compound 2.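

At the saturated chain carbon bound to an aromatic carbon, this assay now has its first step that can be read in one place: (2-(pyrrolidin-1-yl)ethyl)amino in place of 4-(pyrrolidin-1-yl)piperidin-1-yl gives a number 0.33 log units lower from compound 1 to compound 3 (beyond the scatter) at this position. The change combines several differences, as the entering group has 8 heavy atoms, fewer than the leaving group, lacks the six-membered non-aromatic ring and counts 1 hydrogen-bond donor against 0, and this single step cannot separate them. No measurement on hand bears on what lies behind the step.

On these data alone, it remains open how a morpholine, a piperazine or a longer chain such as (3-(pyrrolidin-1-yl)propyl)amino would read in this assay at this position. As far as these compounds go, whether the same exchange gives a similar step on the core of compound 2 also remains open.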